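A Nitrophenyl to Dimethoxyphenyl Swap on a Sesquiterpene Core

This account rests on a few compounds, and the source may have more. Where it says the series, first, only, none or still open, it means among the compounds named here.

Compound 1 `CC1(C)CCC[C@]2(C)[C@@H](CC[C@@](C)(O)/C=C/c3ccccc3)[C@](C)(O)CC[C@@H]12`: 3150 nM
Compound 2 `CC1(C)CCC[C@]2(C)[C@@H](CC[C@@](C)(O)/C=C/c3cccc([N+](=O)[O-])c3)[C@](C)(O)CC[C@@H]12`: 3400 nM
Compound 3 `CC1(C)CCC[C@]2(C)[C@@H](CC[C@@](C)(O)/C=C/c3cncc4ccccc34)[C@](C)(O)CC[C@@H]12`: 45700 nM

Of the compounds shown here, three sharing one core have been measured in a functional assay on A549 cells (Homo sapiens) for cytotoxicity, read by MTT assay, with a stated time of 48 h; on this read-out lower numbers stand for stronger inhibition and higher numbers for weaker inhibition. Compound 2 stands second highest of the three numbers; its nearest neighbour is compound 1, and the step of a 1.1-fold higher number from compound 1 to compound 2 (0.03 log units; within the scatter) is within the scatter, so the two cannot be told apart. Its furthest neighbour is compound 3, and the step of a 13-fold higher number from compound 2 to compound 3 (1.13 log units; beyond the scatter) is large and beyond the scatter.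

Compound 4 `COc1cccc(OC)c1/C=C/[C@](C)(O)CC[C@@H]1[C@@]2(C)CCCC(C)(C)[C@@H]2CC[C@@]1(C)O` is not yet measured. It differs from compound 2 in one place: 2,6-dimethoxyphenyl in place of 3-nitrophenyl on a double-bonded chain carbon bound to a double-bonded chain carbon. The aromatic ring stays a single six-membered ring of carbon only, so the change resembles the step of a 1.1-fold higher number from compound 1 to compound 2 (0.03 log units; within the scatter), which was within the scatter, more than it resembles the steps of a 15-fold higher number from compound 1 to compound 3 (1.16 log units; beyond the scatter) and a 13-fold higher number from compound 2 to compound 3 (1.13 log units; beyond the scatter), where a bicyclic system entered and the numbers rose sharply. No substituted-phenyl pattern beyond compound 2 has been seen, so the expectation is modest: a step of a 1.3-fold higher number from compound 2 to compound 4 (0.12 log units; within the scatter) is expected, which is near the scatter with a slight lean towards a higher number. In this assay compound 4 is therefore estimated at 4500 nM, with a range from 1800 nM to 12000 nM.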

Compound 4, half-maximal inhibitory concentration: 42000 nM
Compound 4: the middle estimate sits 9.3-fold (0.97 log units) below what was measured, and the stated range ends below it.
By their numbers in this assay, from the lowest: compounds 1 and 2 (each within the scatter of the next); then compounds 4 and 3 (each within the scatter of the next).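

At this place, on a double-bonded chain carbon bound to a double-bonded chain carbon, keeping one six-membered aromatic ring of carbon only does not keep the number near that of phenyl: this assay gives a 13-fold higher number from compound 1 to compound 4 (1.12 log units; beyond the scatter) and a 12-fold higher number from compound 2 to compound 4 (1.09 log units; beyond the scatter) for 2,6-dimethoxyphenyl, whereas the earlier swap from phenyl to 3-nitrophenyl stayed within the scatter. A large rise at this place is therefore not confined to the bicyclic isoquinolin-4-yl, since a 1.1-fold lower number from compound 3 to compound 4 (0.04 log units; within the scatter) leaves compound 3 and compound 4 indistinguishable, and substitution on the phenyl ring can either leave the number within the scatter or raise it sharply, depending on the group. Nothing measured here accounts for this difference between 3-nitrophenyl and 2,6-dimethoxyphenyl.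

The compounds shown leave open whether a phenyl ring carrying a single methoxy group would behave like phenyl or like 2,6-dimethoxyphenyl, and whether the arrangement of the two methoxy groups matters at all. They also leave open how a phenyl ring carrying an amine or a carboxylic acid would read at this place.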